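This account rests on a few compounds, and the source may have more. Where it says the series, first, only, none or still open, it means among the compounds named here.

Values in a functional assay on DU-145 cells (Homo sapiens) for inhibition, read by MTT assay, with a stated time of 48 h; on this read-out higher numbers stand for weaker inhibition and lower numbers for stronger inhibition:
- Compound 1 `COc1ccc(-c2nc3ccccn3c2Sc2ccccc2)cc1`: 76800 nM
- Compound 2 `CSc1ccc(-c2nc3ccccn3c2Sc2ccccc2)cc1`: 52100 nM
- Compound 3 `N#Cc1ccc(-c2nc3ccccn3c2Sc2ccccc2)cc1`: 76500 nM

Compound 3, at 76500 nM, cannot be told apart from the other two compounds. The measured changes are a 1.0-fold lower number from compound 1 to compound 3 (0.00 log units; within the scatter) and a 1.5-fold higher number from compound 2 to compound 3 (0.17 log units; within the scatter), both within the scatter. The third comparison, a 1.5-fold lower number from compound 1 to compound 2 (0.17 log units; within the scatter), is also within the scatter.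

The next compound, compound 4 `c1ccc(Sc2c(-c3ccsc3)nc3ccccn23)cc1`, keeps the shared core and the phenylsulfanyl group, but thiophen-3-yl stands in place of 4-cyanophenyl: thiophen-3-yl in place of 4-cyanophenyl on an aromatic carbon. This change is larger than any measured so far, since the three earlier compounds differ only in one group on the same ring. Going by the values given here, no measured compound shows what replacing that whole ring does, so the three small steps are only weak guidance.

In this assay, no change beyond the scatter is expected, and the estimate is a 1.2-fold lower number from compound 3 to compound 4 (0.09 log units; within the scatter). For compound 4, the estimated value is 62000 nM, with an expected range of 27000 nM to 130000 nM.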

Compound 4, half-maximal inhibitory concentration: 85900 nM
Compound 4: middle estimate off by 1.4-fold (0.14 log units), on the low side; the range from low to high includes it.
By their numbers in this assay, from the lowest: compounds 2, 3, 1 and 4 (each within the scatter of the next).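

In this assay, replacing the whole substituted phenyl ring with thiophen-3-yl stays within the scatter in all three comparisons: a 1.1-fold higher number from compound 3 to compound 4 (0.05 log units; within the scatter) and a 1.6-fold higher number from compound 2 to compound 4 (0.22 log units; within the scatter) and also a 1.1-fold higher number from compound 1 to compound 4 (0.05 log units; within the scatter) here. The earlier compounds shown here differed only in one group on the same ring, whereas compound 4 shows that a five-membered aromatic ring with a sulfur atom at this position cannot be told apart from the three phenyl-bearing compounds. Nothing available explains why these numbers stay so close.

All four compounds shown carry an aromatic ring at this position, so the effect of an amine, a carboxylic acid or a longer alkyl chain there remains open. Also open, going by these compounds, is whether replacing the phenylsulfanyl group would move the number beyond the scatter.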